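Changing the nitrogen chain at the limit of the assay

The source may hold more compounds than are shown below. What is called first, only, known or untested is meant among the compounds shown, and "the series" means these compounds.

In an ADME assay on Huh-7 cells (Homo sapiens) for cytotoxicity, with a stated time of 72 h (on this read-out higher numbers stand for lower toxicity in this test and lower numbers for higher toxicity in this test), compound 1 `CCCS(=O)(=O)Nc1ccc2c(c1)S(=O)(=O)N=C(c1c(O)c(-c3cccs3)nn(CCC(C)C)c1=O)N2` gives > 1000 nM as a limit. Compound 2 `CC(C)(C)CCn1nc(-c2cccs2)c(O)c(C2=NS(=O)(=O)c3cc(NS(C)(=O)=O)ccc3N2)c1=O` likewise gives > 1000 nM as a limit. Compound 3 `CS(=O)(=O)Nc1ccc2c(c1)S(=O)(=O)N=C(c1c(O)c(-c3cccs3)nn(CC3CCC3)c1=O)N2` gives > 1000 nM as a limit too, so it cannot be ranked against the other two. Compound 4 `CC(C)CC(C)n1nc(-c2cccs2)c(O)c(C2=NS(=O)(=O)c3cc(NS(C)(=O)=O)ccc3N2)c1=O` differs from compound 3 by 1,3-dimethylbutyl in place of cyclobutylmethyl on an aromatic nitrogen, in detail 1,3-dimethylbutyl in place of cyclobutylmethyl on an aromatic nitrogen and nothing else. Among the compounds with values here, the one measured step on this chain is a step that the two limits leave unreadable from compound 2 to compound 3 and has no size to lend. On the strength of the limit of > 1000 nM in this assay, at which 3 of the 3 values shown sit, no step beyond the scatter is expected, and the estimated step that the limit leaves unreadable from compound 3 to compound 4 carries no firm direction. Compound 4 is estimated at 2000 nM within a range of 1000 nM to 10000 nM in this expectation.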

Compound 4, half-maximal cytotoxic concentration: > 33000 nM
Compound 4 gave a limit, no number; the forecaster's own chance of this, stated with the estimate: 85%; middle value at least 16-fold (1.21 log units) from the limit.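

In this assay compound 4 gives > 33000 nM, a limit. Its steps from compound 2 and from compound 3, which also stand as limits, cannot be read. The compounds shown leave open whether changing the nitrogen chain shifts this read-out at all.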